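This account rests on a few compounds, and the source may have more. Where it says the series, first, only, none or still open, it means among the compounds named here.

Of the compounds shown here, three built on one shared core have been tested in a functional assay on NCI-H1975 cells (Homo sapiens) for inhibition, read by sulforhodamine B assay, tested at 10 uM; a higher number here means more inhibition at the concentration tested (going by the name of the read-out), a lower number less inhibition. Compound 1 `CN(C)c1ccc(C2CC(c3ccc(-n4ccnc4)cc3)=NN2C(=O)CCCl)cc1` gives -2.5%. Compound 2 `COC(=O)CC(=O)N1N=C(c2ccc(-n3ccnc3)cc2)CC1c1ccc(N(C)C)cc1` gives -0.1%, and the step of a number 2.4 percentage points higher from compound 1 to compound 2 (within the scatter) lies within the scatter. Compound 3 `CN(C)c1ccc(C2CC(c3ccc(-n4ccnc4)cc3)=NN2C(=O)c2ccc(F)cc2)cc1` gives -3.5%, which is the lowest of the three numbers, but the step of a number 1 percentage points lower from compound 1 to compound 3 (within the scatter) and the step of a number 3.4 percentage points lower from compound 2 to compound 3 (within the scatter) are both within the scatter, so compound 3 cannot be set apart from the other two on these numbers. All three sit close to zero, meaning essentially no inhibition at the tested concentration.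

Compound 4 `CN(C)c1ccc(C2CC(c3ccc(-n4ccnc4)cc3)=NN2S(C)(=O)=O)cc1` has not yet been measured. It differs from compound 3 in one place: methylsulfonyl in place of (4-fluorophenyl)carbonyl on an amine nitrogen in a ring

The three measured steps all bear on this change, since each swaps the group carried on that same ring nitrogen, from a 2-chloroethyl chain to a (methoxycarbonyl)methyl chain to a 4-fluorophenyl on the carbonyl carbon, and none of them moved the read-out beyond the scatter. Exchanging the (4-fluorophenyl)carbonyl for a methylsulfonyl is a further variation at that position, and the step of a number 1.5 percentage points higher from compound 3 to compound 4 (within the scatter) is therefore expected to stay within the scatter, in no particular direction. Compound 4 is estimated to give -2%, with a range from -12% to 8%.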

Compound 4, a percentage reported as inhibition, at one concentration (the size of the read-out at that concentration, not a potency): -3.8%
Beside the measured number, compound 4's estimate is 1.8 percentage points above it, within the range that was stated.
By their numbers in this assay, from the lowest: compounds 4, 3, 1 and 2 (each within the scatter of the next).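

The earlier compounds shown here all carried a carbonyl on the ring nitrogen, whereas compound 4 has a sulfonyl there, and its methylsulfonyl group also has no ring, unlike the (4-fluorophenyl)carbonyl it replaces. In this assay this different link leaves the read-out unmoved, with a number 0.3 percentage points lower from compound 3 to compound 4 (within the scatter) and a number 3.7 percentage points lower from compound 2 to compound 4 (within the scatter) and also a number 1.3 percentage points lower from compound 1 to compound 4 (within the scatter) all staying close to zero inhibition. No measurement shown here offers an explanation for this flat result.

From the compounds shown here alone, what remains open is whether any group on this nitrogen can produce real inhibition at the tested concentration, since four numbers this close to zero show no difference to build on; a basic amine on a longer chain, a carboxylic acid, or simply a hydrogen on the ring nitrogen would test this further. The 4-(dimethylamino)phenyl and 4-(1H-imidazol-1-yl)phenyl groups are also the same in all four compounds, so the compounds shown say nothing about how replacing either of them would affect the read-out.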